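Propyl versus isopropyl on the amine nitrogen

This account rests on a few compounds, and the source may have more. Where it says the series, first, only, none or still open, it means among the compounds named here.

Measured compounds:
compound 1, `CCCN(Cc1cn2c(N3CCN(C)CC3)cccc2n1)[C@H]1CCCc2cccnc21`, 6700 nM
compound 2, `CN(Cc1cn2c(N3CCN4CCCC4C3)cccc2n1)[C@H]1CCCc2cccnc21`, 3900 nM
compound 3, `CN1CCN(c2cccc3nc(CN(C)[C@H]4CCCc5cccnc54)[nH]c23)CC1`, > 5000 nM

Compound 1 in an ADME assay on HOS cells (Homo sapiens) for cytotoxicity (a higher number here means that more compound is tolerated, a lower number that less compound is tolerated), gives 6700 nM. Of the two compounds with a number in this assay, compound 1 has the higher one, but compound 2 with 3900 nM sits within the scatter of it, so the two are not distinguished. Compound 3 gives only a limit of the assay, > 5000 nM, and no number. That the limit of > 5000 nM in this assay, at which 1 of the 3 values shown sits, leaves one of the three results without a number.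

Compound 4, `CC(C)N(Cc1cn2c(N3CCN(C)CC3)cccc2n1)[C@H]1CCCc2cccnc21`, is not yet measured in this assay. It differs from compound 1 only by isopropyl in place of propyl on an amine nitrogen. Going by the values given here, no step between measured compounds bears on this change. With the amine nitrogen otherwise unchanged and the same atoms joined differently, no step beyond the scatter is expected in this assay, in either direction.

For compound 4 the estimated value in this assay is 6000 nM, within an expected range from 3000 nM to 12000 nM. This estimate means a step of a 1.1-fold lower number from compound 1 to compound 4 (0.05 log units; within the scatter), expected to lie inside the scatter.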

Compound 4, half-maximal cytotoxic concentration: 8900 nM
Beside the measured number, compound 4's estimate is 1.5-fold (0.17 log units) below it; the measured number falls inside the stated range.
By their numbers in this assay, from the lowest: compounds 2, 1 and 4 (each within the scatter of the next, the first and the last beyond it).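

In this assay, going by these compounds alone, the pair gives the first step that can be read in one place: isopropyl in place of propyl on the amine nitrogen gives a 1.3-fold higher number from compound 1 to compound 4 (0.12 log units; within the scatter). Compound 1 and compound 4 are therefore not distinguished, and for this pair, joining the same atoms differently on this nitrogen produces no step beyond the scatter. Nothing at hand gives a cause for this result.

Still open, going by these compounds, is whether a longer chain such as butyl, a cyclopropyl ring or a hydroxyethyl chain on this nitrogen would give a step beyond the scatter. Methyl on this nitrogen occurs only in compound 2 and compound 3, which also differ from compound 1 elsewhere, so no step from propyl to methyl can be read.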